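Swapping chloro for methyl on an aromatic carbon

The source may report more compounds than this note shows. Statements on the series, on what has been measured and on what is new or still open speak of the compounds shown alone.

In a functional assay on Jurkat cells (Homo sapiens) for inhibition, read by MTT assay, with a stated time of 72 h (a lower number here means a stronger inhibitor, a higher number a weaker inhibitor), compound 1 (`C=C(Br)C(=O)Nc1cccc(/C=C/C(=O)Nc2ccc(F)c(F)c2)c1`) gives 550 nM and compound 2 (`C=C(Br)C(=O)Nc1cccc(/C=C/C(=O)Nc2ccc(Cl)cc2)c1`) gives 2600 nM as the higher of the two numbers, so compound 2 is the weaker inhibitor. Compound 3 (`C=C(Br)C(=O)Nc1cccc(/C=C/C(=O)Nc2ccc(C)cc2)c1`) has methyl in place of chloro on an aromatic carbon, para to a large group (methyl in place of chloro on an aromatic carbon). Among the measured compounds shown here, only one measured step bears on this, a 4.7-fold higher number from compound 1 to compound 2 (0.67 log units; beyond the scatter) with 4-chlorophenyl in place of 3,4-difluorophenyl. For the measured compounds named here, that was a different swap, and no methyl compound has been measured yet, so no large shift is expected. The expected change is a 1.0-fold lower number from compound 2 to compound 3 (0.02 log units; within the scatter) and stays within the scatter. For compound 3 the estimated value is 2500 nM with 1000 nM to 6000 nM as the likely range.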

Compound 3, half-maximal inhibitory concentration: 240 nM
Beside the measured number, compound 3's estimate is 10-fold (1.02 log units) above it; measured number below the stated range.
By their numbers in this assay, from the lowest: compound 3; then compound 1; then compound 2.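

At this position, para to a large group, one heavy atom decides much of the result: in this assay methyl in place of chloro gives an 11-fold lower number from compound 2 to compound 3 (1.03 log units; beyond the scatter), a larger shift than the earlier step showed, although the two groups match in every count given. The 4-methylphenyl group also improves on 3,4-difluorophenyl, with a 2.3-fold lower number from compound 1 to compound 3 (0.36 log units; beyond the scatter), so compound 3 has the lowest number of the three. No measurement shown here explains the gap between methyl and chloro. As far as these compounds go, how an ethyl group, a methoxy group or an amine would behave on this same carbon remains open.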